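This account rests on a few compounds, and the source may have more. Where it says the series, first, only, none or still open, it means among the compounds named here.

Measured compounds in an ADME assay on PC-3 cells (Homo sapiens) for cytotoxicity, read by WST assay, tested at 100 uM; on this read-out higher numbers stand for more inhibition at the one concentration tested (going by the name of the read-out) and lower numbers for less inhibition:
- compound 1 `O=C(Nc1cccc(-c2ccco2)c1)C1CCCN(C(=O)c2cc(C(F)(F)F)cc(C(F)(F)F)c2)C1`: 0%
- compound 2 `COC(=O)c1cccc(C(=O)N2CCCC(C(=O)Nc3ccc(Cl)cc3)C2)c1`: 0%
- compound 3 `CS(=O)(=O)c1cccc(C(=O)N2CCCC(C(=O)Nc3ccc(Cl)cc3)C2)c1`: 2%

All three measured members of the series sit at the bottom of the read-out in this assay. Compound 1 is level with compound 2 at the digits printed, and the two together give the lowest numbers of the three; compound 3 is the furthest from compound 1, a difference that stays within the scatter. Among the compounds with values here, the only step between measured compounds that differ in one place is a number 2 percentage points higher from compound 2 to compound 3 (within the scatter), a change on an aromatic carbon of the benzoyl portion, not at the anilide end of the shared core.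

Compound 4 `O=C(Nc1cccc(-c2cnco2)c1)C1CCCN(C(=O)c2cc(C(F)(F)F)cc(C(F)(F)F)c2)C1` differs from compound 1 in 1,3-oxazol-5-yl in place of furan-2-yl on an aromatic carbon. Within the data shown here, no measured step touches this position of the core, so the one measured step bears on it only in a general way: an exchange of one aromatic substituent for another elsewhere moved this read-out within the scatter. With every measured value near zero and no step beyond the scatter anywhere in the set, the change to compound 4 is expected to give a number 2 percentage points higher from compound 1 to compound 4 (within the scatter), that is, no movement beyond the scatter. Compound 4 is therefore estimated at 2%, within a range of -6% to 14%.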

Compound 4, a percentage reported as inhibition, at one concentration (the size of the read-out at that concentration, not a potency): 9%
Compound 4: the middle estimate sits 7 percentage points below what was measured; the measured number falls inside the stated range.
By their numbers in this assay, from the lowest: compounds 1, 2, 3 and 4 (each within the scatter of the next).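

In this assay, within the data shown here, the change at this position gives a number 9 percentage points higher from compound 1 to compound 4 (within the scatter), and this is the first measured step on the aromatic carbon meta to a large group. It shows that replacing furan-2-yl, a five-membered aromatic ring with 1 hetero atom and 1 hydrogen-bond acceptor, with 1,3-oxazol-5-yl, a five-membered aromatic ring with 2 hetero atoms and 2 hydrogen-bond acceptors, does not carry the read-out beyond the scatter in the core of compound 1. No measurement shown here bears on why this step has the size it has.

Going by these compounds, it remains open whether a carboxylic acid, a primary amine or a morpholine ring in place of the five-membered aromatic ring at this position would move this assay beyond the scatter, since both groups compared here are five-membered aromatic rings of equal heavy-atom count. On these data alone, it is also open whether the same exchange of furan-2-yl for 1,3-oxazol-5-yl would give a step of similar size with the benzoyl portion of compound 1 carrying methylsulfonyl or methoxycarbonyl in place of trifluoromethyl.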